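The source may hold more compounds than are shown below. What is called first, only, known or untested is meant among the compounds shown, and "the series" means these compounds.

Measured compounds:
- Compound 1, `C[C@H](c1ccc(F)cc1)N(Cc1cccc(C(=O)O)c1)C(=O)c1cc2ccccn2n1`, gives 94 nM in an assay on CHO T-rex cells for antagonist activity at transient receptor potential cation channel subfamily M member 8 (Homo sapiens), read by calcium flux, with a stated time of 20 min; on this read-out higher numbers stand for weaker inhibition and lower numbers for stronger inhibition.
- Compound 2, `CC(c1ccc(F)cc1)N(Cc1cccc(C(=O)O)c1)C(=O)c1ccc2c(c1)CCO2`, gives 3620 nM in this assay.

Compound 1 stands at the lowest of the two numbers, and compound 2 sits well beyond the usual scatter above it, so of these two compound 1 is the stronger inhibitor. Both share the same core: an amide nitrogen carrying a benzoic acid arm and a fluorophenyl-ethyl arm, with the variable group hanging from the carbonyl carbon. Compound 3, `C[C@H](c1ccc(F)cc1)N(Cc1cccc(C(=O)O)c1)C(=O)c1cc2ccccc2nn1`, keeps everything of compound 1 except that group, where the change is a group of 10 heavy atoms (8 carbon, 2 nitrogen; one six-membered aromatic ring of carbon only, one six-membered aromatic ring with 2 hetero atoms) in place of a group of 9 heavy atoms (7 carbon, 2 nitrogen; one five-membered aromatic ring with 2 hetero atoms, one six-membered aromatic ring with 1 hetero atom), on a carbonyl carbon. Both the leaving and the entering groups are flat, fused two-ring aromatics with the same count of nitrogen atoms, so the change is modest in size. Among the measured compounds shown here, no measured pair shows this exact swap, so the expectation rests on the closeness of the two groups alone. A small loss of potency, beyond the scatter but far short of the gap from compound 1 to compound 2, is the most likely outcome; the step of a 3.7-fold higher number from compound 1 to compound 3 (0.57 log units; beyond the scatter) is expected. Compound 3 is therefore estimated at 350 nM, within the range 100 nM to 1500 nM.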

Compound 3, half-maximal inhibitory concentration in the transient receptor potential cation channel subfamily M member 8 assay: 340 nM
Beside the measured number, compound 3's estimate is 1.0-fold (0.01 log units) above it; low and high end bracket the measured number.
By their numbers in the transient receptor potential cation channel subfamily M member 8 assay, from the lowest: compound 1; then compound 3; then compound 2.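

Among the compounds shown here, in the transient receptor potential cation channel subfamily M member 8 assay the step of a 3.6-fold higher number from compound 1 to compound 3 (0.56 log units; beyond the scatter) is the first comparison that isolates a single change, and that change is the group on the carbonyl carbon. It shows that this position is sensitive even when one fused two-ring aromatic group replaces another with the same number of nitrogen atoms, since potency falls beyond the usual scatter. The hydrogen-bond donor and acceptor counts stay the same across this change, but nothing shown gives a measured explanation for the loss of potency.

Going by these compounds, in a physicochemical assay for lipophilicity (on this read-out lower numbers stand for lower lipophilicity and higher numbers for higher lipophilicity), compound 1 gives 0.9 while for compound 3 the entry is "not determined" (no result reported), so no step can be read on that read-out and it remains open whether the two compounds differ there. Also open, on these data alone, is which part of the swap matters, the five-membered ring giving way to a six-membered ring, the different placing of the nitrogen atoms or the extra heavy atom, and how a single-ring group such as phenyl or pyridine would behave on the same carbonyl carbon.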